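This account rests on a few compounds, and the source may have more. Where it says the series, first, only, none or still open, it means among the compounds named here.

Within the data shown here, in a functional assay on OVCAR-3 cells (Homo sapiens) for inhibition (a lower number here means a stronger inhibitor of growth, a higher number a weaker inhibitor of growth), compound 1 (`NC(=O)c1cc(Cl)ccc1NC(=O)COc1ccccc1`) gives 2300 nM and compound 2 (`NC(=O)c1cc(I)ccc1NC(=O)COc1ccccc1`) gives 321 nM, the lower of the two numbers so far. Compound 3 (`COc1ccc(NC(=O)COc2ccccc2)c(C(N)=O)c1`) has methoxy in place of iodo on an aromatic carbon. Among the measured compounds shown here, only one measured step bears on this change, a 7.2-fold lower number from compound 1 to compound 2 (0.86 log units; beyond the scatter), a modest step beyond the scatter that replaced chloro with iodo at the same place. Methoxy itself is untested, so a step of similar size toward a higher number is expected, with wide uncertainty. The expected change in this assay is a 4.0-fold higher number from compound 2 to compound 3 (0.61 log units; beyond the scatter). For compound 3 the estimated value is 1300 nM, within an expected range of 400 nM to 4000 nM.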

Compound 3, concentration for 50% growth inhibition: 375 nM
Beside the measured number, compound 3's estimate is 3.5-fold (0.54 log units) above it; measured number below the stated range.
By their numbers in this assay, from the lowest: compounds 2 and 3 (each within the scatter of the next); then compound 1.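

In this assay, methoxy and iodo cannot be told apart at this place, para to a large group (a 1.2-fold higher number from compound 2 to compound 3 (0.07 log units; within the scatter)), although they share little beyond the position they occupy. Methoxy also gives a lower number than chloro (a 6.1-fold lower number from compound 1 to compound 3 (0.79 log units; beyond the scatter)), so the gain over compound 1 is not limited to iodo, and chloro alone stands apart among these three compounds. No measurement here accounts for this. Going by these compounds, it remains open whether an amine, a carboxylic acid or a longer chain such as butoxy would hold the number near that of compound 2 or compound 3.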